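Bis(trifluoromethyl)benzenesulfonamide series: benzodioxinylmethyl to methoxybenzyl

This account rests on a few compounds, and the source may have more. Where it says the series, first, only, none or still open, it means among the compounds named here.

The series shares a sulfonamide-linked diamine chain carrying an arylmethyl group on the distal amine, tested in a functional assay on BXPC-3 cells (Homo sapiens) for inhibition, read by MTT assay, with a stated time of 72 h; on this read-out higher numbers stand for weaker inhibition of growth and lower numbers for stronger inhibition of growth. Compound 1 `O=S(=O)(NCCNCc1ccc(-c2ccccc2)cc1)c1cc(C(F)(F)F)cc(C(F)(F)F)c1` gives 1600 nM and compound 2 `O=S(=O)(NCCCCNCc1ccc(Br)cc1)c1cc(C(F)(F)F)cc(C(F)(F)F)c1` gives 1700 nM. Compound 3 `O=S(=O)(NCCCNCC1COc2ccccc2O1)c1cc(C(F)(F)F)cc(C(F)(F)F)c1` gives 1200 nM; the numbers of compound 1 and compound 2 both lie within the scatter of that value, so the three are not separated by this assay.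

Compound 4 `COc1ccc(CNCCCNS(=O)(=O)c2cc(C(F)(F)F)cc(C(F)(F)F)c2)cc1` differs from compound 3 by 4-methoxyphenyl in place of 2,3-dihydro-1,4-benzodioxin-2-yl on a saturated chain carbon bound to an amine nitrogen. Going by the values given here, no measured pair isolates this change. Since compound 1, compound 2 and compound 3 sit within the scatter of one another despite different aryl groups, the step from compound 3 to compound 4 is expected to be small, a 1.3-fold higher number from compound 3 to compound 4 (0.10 log units; within the scatter), with no direction beyond the scatter. Compound 4 is estimated at 1500 nM, within 600 nM to 4000 nM.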

Compound 4, concentration for 50% growth inhibition: 1300 nM
The estimate for compound 4 lay 1.2-fold (0.06 log units) above the measured number, and the stated range covers the measured number.
By their numbers in this assay, from the lowest: compounds 3, 4, 1 and 2 (each within the scatter of the next).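

Exchanging the 2,3-dihydro-1,4-benzodioxin-2-yl group for 4-methoxyphenyl in this assay gives a 1.1-fold higher number from compound 3 to compound 4 (0.03 log units; within the scatter), so this position tolerates loss of the non-aromatic ring without any separation on this read-out. The step of a 1.3-fold lower number from compound 2 to compound 4 (0.12 log units; within the scatter) also stays within the scatter and adds no separation. No supporting measurement on hand bears on this flat result. As far as these compounds go, whether a carboxylic acid or a primary amine in place of the 4-methoxyphenyl group would move the number beyond the scatter remains open.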